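From cyclopentylsulfanyl to hexyloxy at the cytotoxicity limit

The compounds below may be only part of what the source reports. "The series", "measured", "known", "first", "only" and "open" are said of these compounds alone.

Compound 1 `CC(C)CSc1nc(N)nc2c1ncn2/C=C1/CC1(CO)CO` and compound 2 `Nc1nc(SC2CCCC2)c2ncn(/C=C3/CC3(CO)CO)c2n1` differ only in the group on sulfur. In an ADME assay on Akata cells (Homo sapiens) for cytotoxicity, with a stated time of 7 days (on this read-out lower numbers stand for higher toxicity in this test and higher numbers for lower toxicity in this test), compound 1 gives > 20000 nM, which is a limit of the assay and not a number. In the same test compound 2 gives > 20000 nM, again a limit and not a number, so compound 2 has no exact figure to start from. The record so far is the limit of > 20000 nM in this assay, at which 2 of the 2 values shown sit.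

Compound 3 `CCCCCCOc1nc(N)nc2c1ncn2/C=C1/CC1(CO)CO` brings a larger change: hexyloxy in place of cyclopentylsulfanyl on an aromatic carbon. Hexyloxy replaces cyclopentylsulfanyl on an aromatic carbon, so the ring gives way to an open chain and sulfur to oxygen. Among the measured compounds shown here, the only measured step is a step that the two limits leave unreadable from compound 1 to compound 2. It offers no size to carry over, and it involves no change of the sulfur itself. No step beyond the scatter can therefore be forecast in this assay, and a further report at the limit is expected. The estimated step is a number no higher from compound 2 to compound 3 (the limit leaves the size open). For compound 3 the estimated value is 20000 nM, with an expected range from 9000 nM to 40000 nM.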

Compound 3, half-maximal cytotoxic concentration: > 20000 nM
Compound 3: no number, only a limit (the forecaster's own chance of this, stated with the estimate: 70%); the middle value sits exactly at the limit.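

In this assay compound 3 gives > 20000 nM, which is a limit and not a number. The steps among compound 1, compound 2 and compound 3 therefore cannot be read. The compounds shown leave open whether isobutylsulfanyl, cyclopentylsulfanyl and hexyloxy differ at all in this read-out, since all three compounds stop at the same point: the limit of > 20000 nM in this assay, at which 3 of the 3 values shown sit.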